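Aryl Swap at the Thiazole: Pyrazole Replaces Difluorophenyl

This account rests on a few compounds, and the source may have more. Where it says the series, first, only, none or still open, it means among the compounds named here.

Measured so far in an in vitro functional assay on HEK285-7 cells for antagonist activity at prostaglandin D2 receptor 2 (Homo sapiens), read by BRET and beta-arrestin recruitment; on this read-out higher numbers stand for larger maximal responses and lower numbers for smaller maximal responses:
- compound 1 `CS(=O)(=O)Nc1cccc(-c2nc(C(c3ccc(F)cc3)c3ccc(F)cc3)sc2CC(=O)O)c1`, compound 1 gives 80%
- compound 2 `O=C(O)Cc1sc(C(c2ccc(F)cc2)c2ccc(F)cc2)nc1-c1ccnc(F)c1`, compound 2 gives 80%
- compound 3 `O=C(O)Cc1sc(C(c2ccc(F)cc2)c2ccc(F)cc2)nc1-c1cc(F)cc(F)c1`, compound 3 gives 80%

All three share one core and differ only in the aromatic group attached to it. Among the measured compounds shown here, compound 3 stands level with compound 1 and compound 2 on the largest response reached in this assay; no compound among the three can be called stronger or weaker than another, since every pairwise step stays within the scatter.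

The next compound, compound 4 `O=C(O)Cc1sc(C(c2ccc(F)cc2)c2ccc(F)cc2)nc1-c1cn[nH]c1`, changes that aromatic group again: 1H-pyrazol-4-yl in place of 3,5-difluorophenyl on an aromatic carbon.

For the measured compounds named here, three measured steps bear on this kind of change, each swapping the aromatic group on the same carbon: no change at the digits printed from compound 1 to compound 2 (within the scatter), no change at the digits printed from compound 1 to compound 3 (within the scatter) and no change at the digits printed from compound 2 to compound 3 (within the scatter). A sulfonamide-bearing phenyl, a fluorinated pyridine and a difluorophenyl all gave the same maximal response. Going by the values given here, the pyrazole brings a hydrogen-bond donor and a smaller ring, which none of the measured groups share, so the precedent is indirect. Among the compounds with values here, still, the only evidence points to no change beyond the scatter, and the expected step is no change at the digits printed from compound 3 to compound 4 (within the scatter). On that basis compound 4 is estimated at 80%, with a range from 62% to 95%.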

Compound 4, largest response reached (reported as efficacy), in percent of the reference or control that the assay uses: 80%
Estimate against measurement, compound 4: no gap at the digits printed; low and high end bracket the measured number.
By their numbers in this assay, from the lowest: compounds 1, 2, 3 and 4 (each within the scatter of the next).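

In this assay, among the compounds shown here, the carbon next to the ring nitrogen of the shared core now carries a five-membered aromatic ring with 2 hetero atoms, where the earlier compounds all carried six-membered aromatic rings, and placing 1H-pyrazol-4-yl there in place of 3,5-difluorophenyl gives no change at the digits printed from compound 3 to compound 4 (within the scatter) on the largest response reached. For the compounds shown here, the comparisons with the other two groups read alike: replacing 2-fluoropyridin-4-yl gives no change at the digits printed from compound 2 to compound 4 (within the scatter), and replacing 3-(methanesulfonamido)phenyl gives no change at the digits printed from compound 1 to compound 4 (within the scatter), so no pair among the four compounds can be told apart. This position therefore tolerates a difference in ring size as well as the differences in ring substituents already seen, at least on this one read-out of maximal response.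

Going by these compounds, what a group without an aromatic ring would do at this carbon remains open, whether a primary amine, a carboxylic acid, a simple n-butyl chain or plain hydrogen. Nothing available here accounts for why these four different rings give values that cannot be separated.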